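Swapping pentafluorophenyl for 2-fluoro-3-(trifluoromethyl)phenyl

A few compounds are considered here, and "the series" means these few. Any claim that something is new, unique, unknown or untested is made for them only; others in the source may bear on it.

Values in a functional assay on Jurkat cells (Homo sapiens) (a higher number here means a weaker inhibitor, a lower number a stronger inhibitor), so far:
compound 1 `CC(C)[C@H](NC(=O)COc1cccc2ccccc12)C(=O)N[C@@H](CC(=O)O)C(=O)COc1ccc(F)cc1F` gives 33200 nM
compound 2 `CC(C)[C@H](NC(=O)COc1cccc2ccccc12)C(=O)N[C@@H](CC(=O)O)C(=O)COc1cc(F)cc(F)c1F` gives 30000 nM
compound 3 `CC(C)[C@H](NC(=O)COc1cccc2ccccc12)C(=O)N[C@@H](CC(=O)O)C(=O)COc1c(F)c(F)c(F)c(F)c1F` gives 3050 nM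

Compound 3 has the lowest number of the three, and its steps to both others lie beyond the scatter. In compound 4 `CC(C)[C@H](NC(=O)COc1cccc2ccccc12)C(=O)N[C@@H](CC(=O)O)C(=O)COc1cccc(C(F)(F)F)c1F`, not yet measured, 2-fluoro-3-(trifluoromethyl)phenyl takes the place of 2,3,4,5,6-pentafluorophenyl on an oxygen on a saturated carbon 2-fluoro-3-(trifluoromethyl)phenyl in place of 2,3,4,5,6-pentafluorophenyl on an oxygen on a saturated carbon while the rest of the structure stays the same.

Among the measured compounds shown here, three measured steps bear on this. There is a 1.1-fold lower number from compound 1 to compound 2 (0.04 log units; within the scatter) between the two compounds without the pentafluorophenyl group. By contrast, the data show an 11-fold lower number from compound 1 to compound 3 (1.04 log units; beyond the scatter) and also a 9.8-fold lower number from compound 2 to compound 3 (0.99 log units; beyond the scatter) on reaching it. For the measured compounds named here, no measured compound carries trifluoromethyl, so its contribution is unknown. Giving up pentafluorophenyl is expected to lose part, though not all, of the gain seen in a 9.8-fold lower number from compound 2 to compound 3 (0.99 log units; beyond the scatter) for that change.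

The estimated move is a 3.3-fold higher number from compound 3 to compound 4 (0.52 log units; beyond the scatter) in this assay with wide uncertainty. Compound 4 is estimated at 10000 nM within an expected range of 2500 nM to 35000 nM for now.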

Compound 4, half-maximal inhibitory concentration: 50400 nM
The estimate for compound 4 lay 5.0-fold (0.70 log units) below the measured number; the whole stated range lies below it.
By their numbers in this assay, from the lowest: compound 3; then compounds 2, 1 and 4 (each within the scatter of the next).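

In this assay, a 17-fold higher number from compound 3 to compound 4 (1.22 log units; beyond the scatter) shows that the advantage at this position does not extend to 2-fluoro-3-(trifluoromethyl)phenyl, even though it has the same count of heavy atoms as 2,3,4,5,6-pentafluorophenyl, and compound 3 remains the strongest inhibitor of the four. Among the compounds shown here, with a 1.7-fold higher number from compound 2 to compound 4 (0.23 log units; within the scatter) and a 1.5-fold higher number from compound 1 to compound 4 (0.18 log units; within the scatter), compound 4 cannot be told apart from the 2,3,5-trifluorophenyl and 2,4-difluorophenyl compounds, leaving 2,3,4,5,6-pentafluorophenyl as the only group here that stands apart. Nothing available here accounts for this separation.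

Going by these compounds, whether an unsubstituted phenyl would match compound 3 or compound 4 remains open. So does the effect of a pyridine ring, or of a nitrile on the phenyl ring, at this position.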